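This account rests on a few compounds, and the source may have more. Where it says the series, first, only, none or still open, it means among the compounds named here.

Measured compounds:
compound 1, `Cn1nc2c(=O)n(CC3(O)CCN(Cc4ccc(-c5ccncc5)cc4Cl)CC3)cnc2c1-c1ccc(CN)cc1`, 257 nM in an assay on isolated protein for inhibition of ubiquitin carboxyl-terminal hydrolase 7 (Homo sapiens), with stated times of 30 min and 2 h; a higher number here means a weaker inhibitor, a lower number a stronger inhibitor
compound 2, `Cn1nc2c(=O)n(CC3(O)CCN(Cc4ccc(-c5ccsc5)cc4Cl)CC3)cnc2c1-c1ccc(CN)cc1`, 59.5 nM in this assay

Compound 2 holds the lowest of the two numbers shown; compound 1 sits a good way above it, and the step of a 4.3-fold lower number from compound 1 to compound 2 (0.64 log units; beyond the scatter) lies beyond the scatter. The next compound in the series is compound 3, `Cn1nc2c(=O)n(CC3(O)CCN(Cc4ccc(-c5ccsc5Cl)cc4Cl)CC3)cnc2c1-c1ccc(CN)cc1`. It differs from compound 2 by chloro in place of hydrogen on an aromatic carbon. For the measured compounds named here, the only measured step, a 4.3-fold lower number from compound 1 to compound 2 (0.64 log units; beyond the scatter), exchanges the whole ring that carries the new substituent and says nothing directly about adding a chloro to that ring, so there is no step that bears on this change closely. The expectation for compound 3 in this assay therefore rests on compound 2 alone, with a step of a 1.1-fold lower number from compound 2 to compound 3 (0.03 log units; within the scatter) that is expected to stay within the scatter. Compound 3 is estimated at 55 nM, in the range 20 nM to 160 nM.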

Compound 3, half-maximal inhibitory concentration: 453 nM
Estimate against measurement, compound 3: 8.2-fold (0.92 log units) below; the whole stated range lies below it.
By their numbers in this assay, from the lowest: compound 2; then compounds 1 and 3 (each within the scatter of the next).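

On the thiophen-3-yl ring, the carbon next to the ring sulfur and next to the ring atom that bears a large group proves sensitive to substitution: in this assay, the change to 2-chlorothiophen-3-yl gives a 7.6-fold higher number from compound 2 to compound 3 (0.88 log units; beyond the scatter). This single chloro takes away the advantage that the thiophene held over the pyridin-4-yl group, leaving a 1.8-fold higher number from compound 1 to compound 3 (0.25 log units; within the scatter), so no difference can be read between those two compounds. The data shown offer no explanation for this sensitivity.

As far as these compounds go, it remains open whether the penalty is specific to chloro or would also follow a fluoro, methyl or methoxy group at this carbon. From the compounds shown here alone, it is also open whether a chloro on either of the other free thiophene carbons would give the same result.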